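The source may hold more compounds than are shown below. What is called first, only, known or untested is meant among the compounds shown, and "the series" means these compounds.

Measured compounds in a functional assay on MCF7 cells (Homo sapiens) for cytotoxicity, read by MTT assay; a lower number here means that less compound is needed, a higher number that more compound is needed for the effect:
compound 1 `C=C1C(=O)O[C@]2(C)CC[C@@H]1C[C@H](O)[C@@]1(C)CC[C@H](O1)C(=C)CC[C@H]2OC(C)=O` gives < 20 ug/mL, a limit of the assay.
compound 2 `C=C1C(=O)O[C@]2(C)CC[C@@H]1C[C@H](OC(C)=O)[C@@]1(C)CC[C@H](O1)C(=C)CC[C@H]2OC(C)=O` gives < 20 ug/mL, a limit of the assay.
compound 3 `C=C1C(=O)O[C@]2(C)CC[C@@H]1C[C@H](O)[C@@]1(C)CC[C@H](O1)[C@](C)(O)CCC2=O` gives < 20 ug/mL, a limit of the assay.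

Compound 2 differs from compound 1 by acetyl in place of hydrogen on an oxygen on a saturated carbon. The corresponding step in this assay is a step that the two limits leave unreadable from compound 1 to compound 2. Compound 4 `C=C1C(=O)O[C@]2(C)CC[C@@H]1C[C@H](OC(C)=O)[C@@]1(C)CC[C@H](O1)[C@](C)(O)CCC2=O`, not yet measured, differs from compound 3 by acetyl in place of hydrogen on an oxygen on a saturated carbon; the place is the same word for word, so this is the same change. How the cores of compound 1 and compound 3 differ is not broken down here. Within the data shown here, all three values sit at the limit of < 20 ug/mL in this assay, at which 3 of the 3 values shown sit, which leaves no step readable. The step in this assay is expected to be a step that the limit leaves unreadable from compound 3 to compound 4, resting only on a step that the two limits leave unreadable from compound 1 to compound 2. Compound 4 is therefore expected to give 10 ug/mL, most probably again as a limit.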

Compound 4, concentration for half-maximal effect: < 20 ug/mL
Compound 4 ended at the assay's limit (the forecaster's own chance of this, stated with the estimate: 75%); the middle value lies beyond the limit too.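

In this assay no step from compound 3 to compound 4 can be read, as both values are limits: the limit of < 20 ug/mL in this assay, at which 4 of the 4 values shown sit.

The compounds shown leave open where each compound's actual value lies and whether acetyl in place of hydrogen changes it at all.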